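The source may hold more compounds than are shown below. What is called first, only, known or untested is meant among the compounds shown, and "the series" means these compounds.

In a functional assay on BV-2 cells (Mus musculus) for inhibition, read by ELISA, with a stated time of 16 h (on this read-out lower numbers stand for stronger inhibition and higher numbers for weaker inhibition), compound 2 `Cc1ccc(-c2cc(C)c(N3CCN(c4ncccn4)CC3)nn2)cc1` gives 17200 nM, the highest of the two numbers recorded; its nearest neighbour is compound 1 `COc1cccc(-c2cc(C)c(N3CCN(c4ncccn4)CC3)nn2)c1`, which in this assay gives 2600 nM. Compound 3 `Cc1cc(-c2cccnc2)nnc1N1CCN(c2ncccn2)CC1` has not yet been measured in this assay. It differs from compound 2 by pyridin-3-yl in place of 4-methylphenyl on an aromatic carbon. Within the data shown here, the only measured step that touches the same part of the shared core is a 6.6-fold higher number from compound 1 to compound 2 (0.82 log units; beyond the scatter), which shows that this assay is sensitive to what aryl group occupies that position. Among the measured compounds shown here, no measured pair, however, covers an aromatic nitrogen entering at this position, so the direction of the change cannot be taken from the data with confidence. The number for compound 3 is therefore expected to be near that of compound 2, estimated as a 2.5-fold lower number from compound 2 to compound 3 (0.39 log units; beyond the scatter), with a wide range. The estimate for compound 3 in this assay is 7000 nM, between 1500 nM and 30000 nM.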

Compound 3, half-maximal inhibitory concentration: > 100000 nM
Compound 3 ended at the assay's limit; the forecaster's own chance of this, stated with the estimate: 10%; at least 14-fold (1.15 log units) between middle value and limit.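

Compound 3 gives no number in this assay but a limit of the assay: the limit of > 100000 nM in this assay, at which 1 of the 3 values shown sits. Pyridin-3-yl in place of 4-methylphenyl gives an at least 5.8-fold higher number from compound 2 to compound 3 (0.76 log units; beyond the scatter), and pyridin-3-yl in place of 3-methoxyphenyl gives an at least 38-fold higher number from compound 1 to compound 3 (1.58 log units; beyond the scatter). Among these compounds, the earlier step compared only two aryl groups with rings of carbon alone, whereas these steps show that an aromatic ring with a nitrogen at this position reads weaker than either of them, by an amount the limit leaves unfixed.

On these data alone, whether the ring nitrogen or the lack of a methyl or methoxy group on the ring drives this remains open. The compounds shown also do not tell how an unsubstituted phenyl, or a pyridin-3-yl carrying a methoxy group, would read at this position.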